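From fluoro to carboxy on compound 1

This account rests on a few compounds, and the source may have more. Where it says the series, first, only, none or still open, it means among the compounds named here.

In a functional assay on A2780 cells (Homo sapiens) for antiproliferative activity, read by MTT assay, with a stated time of 48 h (a higher number here means a weaker inhibitor, a lower number a stronger inhibitor), compound 1 `COc1ccc(-c2cc3c(cn2)[nH]c(=O)n3-c2cc(OC)c(OC)c(OC)c2)cc1F` gives 730 nM, the lower of the two numerical values, while compound 2 `CCOc1ccc(-c2cc3c(cn2)[nH]c(=O)n3-c2cc(OC)c(OC)c(OC)c2)cc1F` gives 4330 nM. Compound 3 `COc1ccc(-n2c(=O)[nH]c3cnc(-c4cc(OC)c(OC)c(OC)c4)cc32)cc1O` returns only a limit, > 20000 nM. Compound 4 `COc1ccc(-c2cc3c(cn2)[nH]c(=O)n3-c2cc(OC)c(OC)c(OC)c2)cc1C(=O)O` carries carboxy in place of fluoro on an aromatic carbon, ortho to a methoxy group (carboxy in place of fluoro on an aromatic carbon). Among the compounds with values here, the one measured step that bears on this, a 5.9-fold higher number from compound 1 to compound 2 (0.77 log units; beyond the scatter), is a change on a saturated chain carbon bound to an oxygen, not at the site of the fluoro, so it guides only loosely. The expected step, of similar or larger size, is a 9.6-fold higher number from compound 1 to compound 4 (0.98 log units; beyond the scatter) in this assay. For compound 4 the estimate is 7000 nM, with an expected range of 1500 nM to 20000 nM.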

Compound 4, half-maximal inhibitory concentration: 4120 nM
For compound 4 the middle estimate is 1.7-fold (0.23 log units) above the measured one, and the stated range covers the measured number.
By their numbers in this assay, from the lowest: compound 1; then compounds 4 and 2 (each within the scatter of the next). At a limit, above all of these: compound 3.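

Carboxy in place of fluoro, on the aromatic carbon ortho to a methoxy group, is the first change shown at this position, and in this assay the number rises (a 5.6-fold higher number from compound 1 to compound 4 (0.75 log units; beyond the scatter)) by a step that lies beyond the scatter. So this carbon does respond to what it carries, and the fluoro gives the lower number of the two. The carboxy change and the ethoxy change of compound 2 arrive at values within the scatter of each other (a 1.1-fold lower number from compound 2 to compound 4 (0.02 log units; within the scatter)), although they sit at different places on the ring. As far as these compounds go, whether an amine, an amide or a hydroxy group on this carbon would come closer to compound 1 remains open. Nothing measured here speaks to what lies behind the step.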